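The compounds below may be only part of what the source reports. "The series", "measured", "known", "first", "only" and "open" are said of these compounds alone.

Of the compounds shown here, three with a shared core have been measured in an assay on isolated protein for inhibition of lysosomal alpha-glucosidase (Rattus norvegicus), read by colorimetric assay; a lower number here means a stronger inhibitor, a higher number a weaker inhibitor. Compound 1 `OC[C@]1(c2ccc(F)cc2)NC[C@H](O)[C@H]1O` carries a fluoro group on its aromatic ring and gives 101000 nM. Compound 2 `Cc1ccc([C@]2(CO)NC[C@@H](O)[C@@H]2O)cc1`, which carries a methyl group instead, gives 43000 nM. Compound 3 `COc1ccc([C@@]2(CO)NC[C@H](O)[C@H]2O)cc1`, with a methoxy group, gives 2100 nM, the lowest of the three numbers; compound 2 is the nearest and compound 1 the furthest from it. Going by the values given here, the one single-change step among the measured compounds is a 48-fold lower number from compound 1 to compound 3 (1.68 log units; beyond the scatter).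

Compound 4 `Cc1ccc([C@@]2(CO)NC[C@H](O)[C@H]2O)cc1` differs from compound 3 in one place: methyl in place of methoxy on an aromatic carbon. Two observations bear on this step. The large drop in number from fluoro to methoxy in the step from compound 1 to compound 3 suggests that the methoxy group is tied to the low number of compound 3, and compound 2, which also carries a methyl group rather than a methoxy, sits well above compound 3. A rise in number is therefore expected for compound 4, with an expected step of a 14-fold higher number from compound 3 to compound 4 (1.15 log units; beyond the scatter). Compound 4 is estimated at 30000 nM, within a range from 8000 nM to 110000 nM.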

Compound 4, half-maximal inhibitory concentration: 17000 nM
Estimate against measurement, compound 4: 1.8-fold (0.25 log units) above; the measured number falls inside the stated range.
By their numbers in this assay, from the lowest: compound 3; then compound 4; then compound 2; then compound 1.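

Among these three compounds of one configuration, the group on this aromatic carbon sets a clear order. Putting methyl in place of methoxy gives an 8.1-fold higher number from compound 3 to compound 4 (0.91 log units; beyond the scatter), while methyl in place of fluoro gives a 5.9-fold lower number from compound 1 to compound 4 (0.77 log units; beyond the scatter), so methyl falls between the other two groups. The number also moves with a 2.5-fold lower number from compound 2 to compound 4 (0.40 log units; beyond the scatter), and this step can only come from configuration: the fact that compounds 2 and 4 differ only in the configuration as drawn.

From the compounds shown here alone, it remains open whether methoxy would also give the lowest number in the mirror-image form, as only the methyl compounds appear in both forms here. Going by these compounds, it is also open whether an ethoxy group, a hydroxyl or an amine on the same aromatic carbon would give a number lower than that of compound 3.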